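This account rests on a few compounds, and the source may have more. Where it says the series, first, only, none or still open, it means among the compounds named here.

Compound 2 `O=C(c1ccc(O)cc1O)[C@@H]1[C@@H](C(=O)c2ccc(O)cc2O)[C@H](c2ccccc2)[C@@H]1c1ccccc1` is the higher of the two compounds measured in a functional assay on PC-3 cells (Homo sapiens) for cytotoxicity, read by MTT assay, with a stated time of 48 h, tested at 5 uM (on this read-out higher numbers stand for a stronger effect at the one concentration tested and lower numbers for a weaker effect), where compound 2 gives 29%. Compound 1 `O=C(c1ccc(O)cc1O)[C@@H]1[C@H](C(=O)c2ccc(O)cc2O)[C@@H](c2ccccc2)[C@H]1c1ccccc1` shares all atoms and bonds with it and gives 27.1% in this assay; the step of a number 1.9 percentage points higher from compound 1 to compound 2 (within the scatter) shows that changing one stereocentre barely matters here, because of the fact that compounds 1 and 2 differ only in the configuration as drawn. Compound 3 `O=C(c1ccc(O)cc1O)[C@H]1[C@H](C(=O)c2ccc(O)cc2O)[C@H](c2ccccc2)[C@@H]1c1ccccc1` differs from compound 2 by the two compounds have the same atoms and bonds and differ only in configuration as drawn: 2 of 4 stereo elements differ; a stereocentre at a saturated ring carbon is drawn S in compound 2 and R in compound 3; a stereocentre at a saturated ring carbon is drawn S in compound 2 and R in compound 3. For the measured compounds named here, since the one measured stereochemical change left the read-out essentially unchanged, the expected step of a number 1 percentage points lower from compound 2 to compound 3 (within the scatter) is none beyond the scatter. For compound 3 the expected result in this assay is 28%, within a range of 15% to 42%.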

Compound 3, a percentage reported as activity, at one concentration (the size of the read-out at that concentration, not a potency): 30.7%
For compound 3 the middle estimate is 2.7 percentage points below the measured one, within the range that was stated.
By their numbers in this assay, from the lowest: compounds 1, 2 and 3 (each within the scatter of the next).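

In this assay, for the compounds shown here, changing two stereocentres at saturated ring carbons together gives a number 1.7 percentage points higher from compound 2 to compound 3 (within the scatter), and this double change stays as small as the single change seen earlier. Changing one stereocentre in a new pair gives a number 3.6 percentage points higher from compound 1 to compound 3 (within the scatter), which also stays inside the scatter. Across these three compounds, the configuration at these ring carbons shows no measurable effect on the read-out. As far as these compounds go, all three carry the same atoms and bonds, and whether an amine or a carboxylic acid on the shared core would shift the number remains open.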